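The source may hold more compounds than are shown below. What is called first, only, known or untested is meant among the compounds shown, and "the series" means these compounds.

Compound 1 `N/C(=N\NC(=S)N1CCOCC1)c1ccccn1`: 43.1%
Compound 2 `N/C(=N\NC(=S)N1CCSCC1)c1ccc(F)cn1`: 61.2%

In a functional assay on A-431 cells (Homo sapiens) for cytotoxicity, read by MTT assay, with a stated time of 72 h, tested at 3 uM (a higher number here means more inhibition of growth at the concentration tested, a lower number less inhibition of growth), compound 2 gives 61.2%, the higher of the two numbers, and compound 1 gives 43.1%, a gap beyond the scatter; these two compounds differ in two places, so no single step can be read from them. Compound 3 `N/C(=N\NC(=S)N1CCOCC1)c1ccc(F)cn1` is not yet measured. It differs from compound 2 by morpholin-4-yl in place of thiomorpholin-4-yl on a thiocarbonyl carbon. With no comparable step shown, a modest drop in this assay is expected, possibly none beyond the scatter. For compound 3 the expected value is 50%, in the range 35% to 65%, a step of a number 11.2 percentage points lower from compound 2 to compound 3 (beyond the scatter).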

Compound 3, percent growth inhibition at one concentration: 47%
The estimate for compound 3 lay 3 percentage points above the measured number; the range from low to high includes it.
By their numbers in this assay, from the lowest: compounds 1 and 3 (each within the scatter of the next); then compound 2.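

In this assay, morpholin-4-yl in place of thiomorpholin-4-yl on a thiocarbonyl carbon gives a number 14.2 percentage points lower from compound 2 to compound 3 (beyond the scatter) with the fluoro group kept. Fluoro in place of hydrogen on an aromatic carbon gives a number 3.9 percentage points higher from compound 1 to compound 3 (within the scatter) with morpholin-4-yl kept, so only the ring exchange shows a step beyond the scatter. No measurement shown here offers an explanation for that step. From the compounds shown here alone, whether thiomorpholin-4-yl gives a similar result without the fluoro group remains open. So does the outcome with piperidin-1-yl or an open-chain dimethylamino group on the thiocarbonyl carbon.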